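The compounds below may be only part of what the source reports. "The series", "measured", "known", "first", "only" and "open" are said of these compounds alone.

Measured so far:
Compound 1 `C/C(=N/c1ccnc2cc(Cl)ccc12)NC1CCN(Cc2ccccc2)CC1` gives > 1 h.
Compound 2 `C/C(=N/c1ccnc2cc(Cl)ccc12)NCCCN1CCCCC1` gives > 1 h.
Compound 3 `CC(C)/C(=N/c1ccnc2cc(Cl)ccc12)NCCCN1CCCCC1` gives 0.483 h.

The read-out is an ADME assay (liver) for metabolic stability, with Liver microsome (Homo sapiens) as the target, read by LC-MS, using microsomes, tested at 1 uM; a higher number here means that the compound lasts longer, a lower number that the compound disappears faster. The values of compound 1 and compound 2 are limits of this assay, not numbers, and both sit at the limit of > 1 h in this assay, at which 2 of the 3 values shown sit. Compound 3 is the only one of the three with a number.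

Compound 2 and compound 3 differ in one place: isopropyl in place of methyl on a carbon with a double bond to nitrogen. That change gives an at least 2.0-fold lower number from compound 2 to compound 3 (0.31 log units; beyond the scatter). Because compound 2 sits at the limit of > 1 h in this assay, at which 2 of the 3 values shown sit, the true size of this step cannot be read closely; it is at least modest.

Compound 1 and compound 2 share an amidine linked to the same core, but the difference between the two cores is not broken down here.

Compound 4 `CC(C)/C(=N/c1ccnc2cc(Cl)ccc12)NC1CCN(Cc2ccccc2)CC1` has not yet been measured. It stands to compound 1 as compound 3 stands to compound 2: isopropyl in place of methyl on a carbon with a double bond to nitrogen. The place is the same word for word in both pairs, so this is the same change.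

Drawing on an at least 2.0-fold lower number from compound 2 to compound 3 (0.31 log units; beyond the scatter), compound 4 is expected to show a shorter half-life than compound 1, with an estimated step of an at least 1.6-fold lower number from compound 1 to compound 4 (0.22 log units; that floor lies within the scatter). Compound 1 is known only as a limit, so the starting point of this step is uncertain, and the estimate for compound 4 is correspondingly wide. The estimated half-life of compound 4 in this assay is 0.6 h, expected to fall between 0.3 h and 1.2 h.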

Compound 4, half-life: 0.417 h
For compound 4 the middle estimate is 1.4-fold (0.16 log units) above the measured one, and the stated range covers the measured number.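

In this assay, putting isopropyl in place of methyl on a carbon with a double bond to nitrogen gives an at least 2.3-fold lower number from compound 1 to compound 4 (0.37 log units; beyond the scatter), so the fall in half-life seen on the core of compound 2 also appears on the core of compound 1. This shows that, across these two pairs, the change carries from one core to the other in direction and that the step lies beyond the scatter on both cores, but it does not show that the step has the same size on each: the same change on two cores in this assay, an at least 2.0-fold lower number (0.31 log units; beyond the scatter) from compound 2 to compound 3 and an at least 2.3-fold lower number (0.37 log units; beyond the scatter) from compound 1 to compound 4; the limit leaves it open whether they differ The two methyl compounds both stand at a limit and not at a number, so neither step has a fixed starting point and the true effect of the change on either core remains unknown: the limit of > 1 h in this assay, at which 2 of the 4 values shown sit.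

The compounds shown leave open how ethyl or cyclopropyl would behave on that same carbon, and so whether the half-life falls only with isopropyl or also with these other groups. They also leave open whether the change would carry to a third core, such as one with a longer chain or a carboxylic acid on the amine side of the amidine.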